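Cytotoxicity on MT2 cells: hydroxymethyl in place of methylsulfanyl

The source may hold more compounds than are shown below. What is called first, only, known or untested is meant among the compounds shown, and "the series" means these compounds.

Measured so far:
compound 1 `Clc1cccc(Cl)c1Cc1nnc(Nc2ccc(COCc3ccoc3)cc2)o1`, 21000 nM
compound 2 `OCc1ccc(Nc2ncc(Cc3c(F)cccc3F)o2)cc1Cl`, 90000 nM
compound 3 `CSCc1ccc(Nc2ncc(Cc3c(F)cccc3F)o2)cc1`, > 100000 nM

In an ADME assay on MT2 cells (Homo sapiens) for cytotoxicity, read by MTT assay (a higher number here means that more compound is tolerated, a lower number that less compound is tolerated), compound 1 gives 21000 nM. Compound 2 gives 90000 nM in this assay. For compound 3 only a limit is known, > 100000 nM, which is the limit of > 100000 nM in this assay, at which 1 of the 3 values shown sits; its place relative to the others cannot be fixed.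

Compound 4 `OCCc1ccc(Nc2ncc(Cc3c(F)cccc3F)o2)cc1` differs from compound 3 by hydroxymethyl in place of methylsulfanyl on a saturated chain carbon bound to an aromatic carbon. For the measured compounds named here, no measured pair separates this change, so no direction is set. Compound 2, which carries hydroxymethyl, gives 90000 nM in this assay. Compound 3 sits at its limit. On that basis a step of a number no higher from compound 3 to compound 4 (the limit leaves the size open) of none beyond the scatter is expected. Compound 4 is expected at 100000 nM, between 40000 nM and 250000 nM.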

Compound 4, half-maximal cytotoxic concentration: 35000 nM
Compound 4: middle estimate off by 2.9-fold (0.46 log units), on the high side; the whole stated range lies above it.
By their numbers in this assay, from the lowest: compounds 1 and 4 (each within the scatter of the next); then compound 2. At a limit, above all of these: compound 3.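

For the compounds shown here, this is the first pair that differs in one place, and it shows that this saturated chain carbon bound to an aromatic carbon is not indifferent to the group it carries: in this assay, hydroxymethyl in place of methylsulfanyl gives an at least 2.8-fold lower number from compound 3 to compound 4 (0.45 log units; beyond the scatter). The size of that step has only a lower bound, as compound 3 gives a limit: the limit of > 100000 nM in this assay, at which 1 of the 4 values shown sits.

Still open, from the compounds shown here alone, is how an amine or a carboxylic acid in place of hydroxymethyl on that carbon would read. Going by these compounds, a longer chain ending in hydroxyl is equally open.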